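Removing the methoxy from an anilide inhibitor of colon cancer cells

The source may hold more compounds than are shown below. What is called first, only, known or untested is meant among the compounds shown, and "the series" means these compounds.

Measured so far in a functional assay on HCT-116 cells (Homo sapiens) for inhibition, read by colorimetric assay, with a stated time of 3 days; a higher number here means a weaker inhibitor, a lower number a stronger inhibitor:
Compound 1 `O=C(CCCCCCNC(=O)C(O)(O)C(F)(F)F)Nc1ccc(F)cc1F` gives 18500 nM.
Compound 2 `O=C(CCCCCCNC(=O)C(O)(O)C(F)(F)F)Nc1c(F)cc(F)cc1F` gives 22200 nM.
Compound 3 `COc1cccc(NC(=O)CCCCCCNC(=O)C(O)(O)C(F)(F)F)c1` gives 6110 nM.

Compound 3 gives the lowest number of the three, reached by a 3.0-fold lower number from compound 1 to compound 3 (0.48 log units; beyond the scatter) and by a 3.6-fold lower number from compound 2 to compound 3 (0.56 log units; beyond the scatter), both modest but beyond the scatter. Compound 4 `O=C(CCCCCCNC(=O)C(O)(O)C(F)(F)F)Nc1ccccc1` differs from compound 3 by hydrogen in place of methoxy on an aromatic carbon. For the measured compounds named here, no measured step removes a single group from this ring while leaving the rest untouched; the two steps that bear on it swap the whole substituted ring, and both were modest. Compound 4 is therefore expected to show a step of a 1.6-fold higher number from compound 3 to compound 4 (0.21 log units; within the scatter) in this assay, upward, landing between the numbers already seen. Compound 4 is estimated at 10000 nM, with a range from 4000 nM to 25000 nM.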

Compound 4, half-maximal inhibitory concentration: 9140 nM
Compound 4: middle estimate off by 1.1-fold (0.04 log units), on the high side; the measured number falls inside the stated range.
By their numbers in this assay, from the lowest: compounds 3 and 4 (each within the scatter of the next); then compounds 1 and 2 (each within the scatter of the next).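

In this assay, taking the methoxy off the ring gives a 1.5-fold higher number from compound 3 to compound 4 (0.17 log units; within the scatter), so on this aromatic carbon the methoxy makes no difference that can be told from the scatter. The bare phenyl ring also keeps an edge over the fluorinated rings, with a 2.4-fold lower number from compound 2 to compound 4 (0.39 log units; beyond the scatter) and a 2.0-fold lower number from compound 1 to compound 4 (0.31 log units; beyond the scatter), which suggests that the gap seen earlier comes from the fluorines being present rather than from the methoxy. No supporting data explain these differences. As far as these compounds go, whether a larger group, such as an amine or a carboxylic acid, would behave like the methoxy on this carbon remains open.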